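Cyano for Hydrogen on the Benzamide of Compound 1

The source may report more compounds than this note shows. Statements on the series, on what has been measured and on what is new or still open speak of the compounds shown alone.

Measured compounds:
Compound 1, `COc1cc2oc(-c3cccc(NC(=O)c4ccccc4)c3)cc(=O)c2c(OC)c1OC`: 12100 nM
Compound 2, `COc1cc2oc(-c3cccc(NC(=O)c4ccc([N+](=O)[O-])cc4)c3)cc(=O)c2c(OC)c1OC`: 20100 nM

In a functional assay on MCF7 cells (Homo sapiens) for inhibition, read by MTT assay (on this read-out lower numbers stand for stronger inhibition of growth and higher numbers for weaker inhibition of growth), compound 1 gives 12100 nM, the lower of the two numbers in hand. Within the data shown here, compound 2, `COc1cc2oc(-c3cccc(NC(=O)c4ccc([N+](=O)[O-])cc4)c3)cc(=O)c2c(OC)c1OC`, gives 20100 nM in this assay, and the step of a 1.7-fold higher number from compound 1 to compound 2 (0.22 log units; within the scatter) is the only comparison available here.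

Compound 3, `COc1cc2oc(-c3cccc(NC(=O)c4cccc(C#N)c4)c3)cc(=O)c2c(OC)c1OC`, has not yet been tested in this assay. It differs from compound 1 by cyano in place of hydrogen on an aromatic carbon. Among the measured compounds shown here, the one measured step that bears on it, a 1.7-fold higher number from compound 1 to compound 2 (0.22 log units; within the scatter), placed a substituent on the same ring of the benzamide and stayed within the scatter. A change of similar size is therefore expected for compound 3, with no direction that can be told apart from the scatter: the estimate for the step from compound 1 to compound 3 is a 1.2-fold higher number from compound 1 to compound 3 (0.06 log units; within the scatter). Compound 3 is thus expected to give about 14000 nM in this assay, within the range 6000 nM to 35000 nM.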

Compound 3, concentration for 50% growth inhibition: 41700 nM
For compound 3 the middle estimate is 3.0-fold (0.47 log units) below the measured one; measured number outside the range, above it.
By their numbers in this assay, from the lowest: compounds 1 and 2 (each within the scatter of the next); then compound 3.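

In this assay, among these compounds, the benzamide ring of the core proves sensitive to what it carries: a 3.4-fold higher number from compound 1 to compound 3 (0.54 log units; beyond the scatter) is the first step at this ring to lie beyond the scatter, whereas a 1.7-fold higher number from compound 1 to compound 2 (0.22 log units; within the scatter) stayed within it. With a 2.1-fold higher number from compound 2 to compound 3 (0.32 log units; beyond the scatter) also beyond the scatter, 3-cyanophenyl and 4-nitrophenyl do not read alike here, although this step changes both the group and where it sits, so it cannot be assigned to either change alone. Nothing measured here accounts for the weaker inhibition of growth seen with the cyano group.

Cyano is shown at only one place on this ring, so whether the group or its place sets the size of the step stays open. On these data alone, how an amine or a carboxylic acid at this place would read in this assay also stays open.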